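Adding nitro to compound 3

A few compounds are considered here, and "the series" means these few. Any claim that something is new, unique, unknown or untested is made for them only; others in the source may bear on it.

In a functional assay on A549 cells (Homo sapiens) for antiproliferative activity, read by MTT assay, with a stated time of 72 h (on this read-out lower numbers stand for stronger inhibition and higher numbers for weaker inhibition), compound 3 `Cc1nc(C)c(/C=C/C(=O)/C=C/c2ccccc2)nc1C` gives 12300 nM, the highest of the three numbers measured. Compound 1 `Cc1nc(C)c(/C=C/C(=O)/C=C/c2ccccc2O)nc1C` gives 4780 nM and compound 2 `COc1ccccc1/C=C/C(=O)/C=C/c1nc(C)c(C)nc1C` gives 3200 nM. Compound 4 `Cc1nc(C)c(/C=C/C(=O)/C=C/c2ccccc2[N+](=O)[O-])nc1C` has nitro in place of hydrogen on an aromatic carbon, ortho to a large group: nitro in place of hydrogen on an aromatic carbon. For the measured compounds named here, two measured steps bear on this change, each putting hydrogen on an aromatic carbon: a 2.6-fold higher number from compound 1 to compound 3 (0.41 log units; beyond the scatter) and a 3.8-fold higher number from compound 2 to compound 3 (0.58 log units; beyond the scatter). Both are modest, and read in reverse they show a lower number when the group is present. Neither involves nitro, so the expectation stays loose. A modest step towards a lower number is expected, a 2.1-fold lower number from compound 3 to compound 4 (0.31 log units; beyond the scatter). The estimate for compound 4 is 6000 nM, with an expected range of 2500 nM to 14000 nM.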

Compound 4, half-maximal inhibitory concentration: 17300 nM
Compound 4: the middle estimate sits 2.9-fold (0.46 log units) below what was measured; measured number above the stated range.
By their numbers in this assay, from the lowest: compounds 2 and 1 (each within the scatter of the next); then compounds 3 and 4 (each within the scatter of the next).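

In this assay, nitro in place of hydrogen on this aromatic carbon, ortho to a large group, brings no gain that stands clear of the scatter (a 1.4-fold higher number from compound 3 to compound 4 (0.15 log units; within the scatter)). The lower numbers seen with hydroxy and methoxy therefore do not extend to every group placed here, and nitro stands apart from both (a 3.6-fold higher number from compound 1 to compound 4 (0.56 log units; beyond the scatter); a 5.4-fold higher number from compound 2 to compound 4 (0.73 log units; beyond the scatter)). Nothing given here accounts for this difference. As far as these compounds go, it remains open whether an amine or a chlorine atom on the same carbon would side with hydroxy and methoxy or with nitro.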